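A few compounds are considered here, and "the series" means these few. Any claim that something is new, unique, unknown or untested is made for them only; others in the source may bear on it.

Measured so far:
compound 1 `Cc1ccc(/C=N\NC(=O)C2=C(Cl)c3ccccc3CCC2)cc1` — 140 nM
compound 2 `COc1cc(/C=N\NC(=O)C2=C(Cl)c3ccccc3CCC2)cc(OC)c1OC` — < 10 nM

Among the compounds with values here, in a functional assay on IMR-32 cells (Homo sapiens) for inhibition, read by sulforhodamine B assay, with a stated time of 48 h (on this read-out higher numbers stand for weaker inhibition of growth and lower numbers for stronger inhibition of growth), compound 1 gives 140 nM, the only plain number among the values shown. Compound 2 is recorded at < 10 nM, which is a limit of this assay and not a number; one of the two values sits at the limit of < 10 nM in this assay, at which 1 of the 2 values shown sits. Compound 3 `O=C(N/N=C\c1ccc(Cl)cc1)C1=C(Cl)c2ccccc2CCC1` is still to be measured. It differs from compound 1 by chloro in place of methyl on an aromatic carbon of the six-membered ring. Within the data shown here, no measured pair in this set covers that change, so nothing here sizes it. The step from compound 1 to compound 3 is expected to be a 1.3-fold lower number from compound 1 to compound 3 (0.10 log units; within the scatter), that is, within the usual scatter, with no clear direction. Compound 3 is therefore expected to give 110 nM, with a range from 40 nM to 300 nM in this assay.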

Compound 3, concentration for 50% growth inhibition: 140 nM
Compound 3: middle estimate off by 1.3-fold (0.10 log units), on the low side, within the range that was stated.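

Chloro in place of methyl on an aromatic carbon, para to a large group, gives no change at the digits printed from compound 1 to compound 3 (within the scatter) in this assay. For this one position, the read-out does not separate methyl from chloro, which compound 1 and compound 2 could not show, as they differ in more than one place. Nothing among the data shown gives a reason for this result.

Whether the value would also hold with an amine or a carboxylic acid at this position stays open, as the compounds shown carry only methyl and chloro there. Compound 2 stands at < 10 nM, which is a limit of the assay and not a number, and the compounds shown do not tell which part of its substitution pattern accounts for that entry.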